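Methoxyphenyl piperazine amides: expectation for compound 4

This account rests on a few compounds, and the source may have more. Where it says the series, first, only, none or still open, it means among the compounds named here.

Measured so far:
compound 1 `O=C(CN1CCN(c2ccccc2)CC1)N1CCN(c2nnc(-c3ccccc3)c(-c3ccccc3)n2)CC1`: > 963000 nM
compound 2 `COc1ccc(-c2nnc(N3CCN(C(=O)CN4CCN(c5ccccc5)CC4)CC3)nc2-c2ccc(OC)cc2)cc1`: > 863000 nM
compound 3 `COc1ccccc1N1CCN(CC(=O)N2CCN(c3nnc(-c4ccc(Cl)cc4)c(-c4ccc(Cl)cc4)n3)CC2)CC1`: 330000 nM

In a functional assay on MCF7 cells (Homo sapiens) for cytotoxicity, read by MTT assay, with a stated time of 24 h (a lower number here means a stronger inhibitor, a higher number a weaker inhibitor), compound 1 reaches only a limit, > 963000 nM. Compound 2 likewise gives only a limit in this assay, > 863000 nM. Within the data shown here, compound 3 is the sole compound with a numbered value in this assay, 330000 nM. The other two values sit at a limit: the limit of > 863000 nM in this assay, at which 1 of the 3 values shown sits, and (the limit of > 963000 nM in this assay, at which 1 of the 3 values shown sits).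

Compound 4 `COc1cccc(N2CCN(CC(=O)N3CCN(c4nnc(-c5ccc(Cl)cc5)c(-c5ccc(Cl)cc5)n4)CC3)CC2)c1` differs from compound 3 by 3-methoxyphenyl in place of 2-methoxyphenyl on an amine nitrogen in a ring. Among the measured compounds shown here, no step between two measured compounds is available to size this change. In this assay the expected step from compound 3 to compound 4 is a 1.1-fold higher number from compound 3 to compound 4 (0.03 log units; within the scatter), a change not beyond the usual scatter, in no particular direction. Compound 4 is therefore estimated at 350000 nM, within 150000 nM to 900000 nM.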

Compound 4, half-maximal inhibitory concentration: 149000 nM
Estimate against measurement, compound 4: 2.3-fold (0.37 log units) above; the whole stated range lies above it.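

Placing 3-methoxyphenyl instead of 2-methoxyphenyl on the amine nitrogen in a ring, with the same atoms, gives the first step in the series that can be sized: in this assay, a 2.2-fold lower number from compound 3 to compound 4 (0.35 log units; beyond the scatter). This place therefore responds to a change in where the methoxy group sits, although the step is modest and rests on one pair. Nothing shown accounts for this step.

Going by these compounds, whether a fluorophenyl or a carboxylic acid-bearing phenyl at this place would lower the number further remains open. Also open, on these data alone, is whether the same swap gives a similar step on the core of compound 1 or compound 2.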